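The source may report more compounds than this note shows. Statements on the series, on what has been measured and on what is new or still open speak of the compounds shown alone.

In an ADME assay on MT4 cells (Homo sapiens) for cytotoxicity, read by MTT assay, with a stated time of 96 h (a higher number here means that more compound is tolerated, a lower number that less compound is tolerated), compound 1 (`Cc1ccc(NCc2cn(-c3ccccc3)nc2-c2ccc(C(F)(F)F)cc2)cc1`) reads > 100000 nM as a limit of the assay. Compound 2 (`Cc1ccc(NCc2cn(-c3ccccc3)nc2-c2ccc(C)cc2)cc1`) likewise reads > 100000 nM as a limit. Compound 3 (`Cc1ccc(NCc2cn(-c3ccccc3)nc2-c2ccccc2)cc1`) reads > 100000 nM as a limit too, so it has no number of its own. All three readings share one boundary (the limit of > 100000 nM in this assay, at which 3 of the 3 values shown sit) in this series.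

Compound 4 (`Clc1ccc(NCc2cn(-c3ccccc3)nc2-c2ccccc2)cc1`) departs from compound 3 at a single place (chloro in place of methyl on an aromatic carbon): chloro in place of methyl on an aromatic carbon, para to a large group, so that 4-methylphenyl becomes 4-chlorophenyl.

The measured steps all lie elsewhere on the shared core, and none has a readable size: (a step that the two limits leave unreadable from compound 1 to compound 2), (a step that the two limits leave unreadable from compound 1 to compound 3) and (a step that the two limits leave unreadable from compound 2 to compound 3). They offer no measured size for this exchange, only the sign that three substituents at that other place left every reading at the limit.

No shift beyond the usual scatter is therefore expected in this assay, and the reading will most likely stay at the limit. The estimated change is a number no higher from compound 3 to compound 4 (the limit leaves the size open) and no more than that. For compound 4 the expected value is 100000 nM, within an estimated range from 40000 nM to 150000 nM in all.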

Compound 4, half-maximal cytotoxic concentration: > 100000 nM
Compound 4: a limit, no number (the forecaster's own chance of this, stated with the estimate: 70%); the middle value sits exactly at the limit.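

Compound 3 and compound 4 both read as limits in this assay, so the step between them cannot be read and the exchange of methyl for chloro has no measurable size. The series shares one boundary: the limit of > 100000 nM in this assay, at which 4 of the 4 values shown sit. The compounds shown leave open whether, and at what concentration, any of them becomes cytotoxic to these cells.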